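Replacing the anilino link of compound 1 with a bare phenyl

The compounds below may be only part of what the source reports. "The series", "measured", "known", "first", "only" and "open" are said of these compounds alone.

Compound 1 `COc1ccc(Nc2ccnc(Nc3ccc(NS(=O)(=O)c4ccc(OC)cc4)cc3)n2)cc1` gives 29000 nM in a functional assay on MCF7 cells (Homo sapiens) for antiproliferative activity, read by MTT assay (a lower number here means a stronger inhibitor, a higher number a weaker inhibitor), the second highest of the three numbers in hand. Compound 2 `COc1ccc(Nc2ccnc(Nc3ccc(NS(=O)(=O)c4ccc(C(F)(F)F)cc4)cc3)n2)cc1` gives 34800 nM, and the step from compound 1 to compound 2 is a 1.2-fold higher number from compound 1 to compound 2 (0.08 log units; within the scatter). Compound 3 `COc1ccc(S(=O)(=O)Nc2ccc(Nc3nccc(Nc4cc(OC)c(OC)c(OC)c4)n3)cc2)cc1` gives 9700 nM, a step of a 3.0-fold lower number from compound 1 to compound 3 (0.48 log units; beyond the scatter). Compound 4 `COc1ccc(S(=O)(=O)Nc2ccc(Nc3nccc(-c4ccccc4)n3)cc2)cc1` differs from compound 1 in one place: phenyl in place of (4-methoxyphenyl)amino on an aromatic carbon. Neither measured step touches this position, so nothing in hand bears directly on it; both steps were small or modest. The estimate for compound 4 is therefore 32000 nM, with a wide range from 8000 nM to 130000 nM. The expected step from compound 1 to compound 4 is a 1.1-fold higher number from compound 1 to compound 4 (0.04 log units; within the scatter), with no direction beyond the scatter asserted.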

Compound 4, half-maximal inhibitory concentration: > 50000 nM
Compound 4 gave a limit, no number (the forecaster's own chance of this, stated with the estimate: 25%); middle value at least 1.5-fold (0.19 log units) away from the limit.
By their numbers in this assay, from the lowest: compound 3; then compounds 1 and 2 (each within the scatter of the next). At a limit, above all of these: compound 4.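

In this assay compound 4 gives > 50000 nM, a limit and not a number: the limit of > 50000 nM in this assay, at which 1 of the 4 values shown sits. Phenyl in place of (4-methoxyphenyl)amino, next to the ring nitrogen, brings no gain in potency, but the step, an at least 1.7-fold higher number from compound 1 to compound 4 (0.23 log units; that floor lies within the scatter), has a floor within the scatter, so a real loss is not established.

Going by these compounds, the true size of the step stays open. The change also removes the linking nitrogen and the methoxy together, and phenylamino or 4-methoxyphenyl on this carbon would separate the two.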